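Toxicity Outlook for an Ethoxy Variant of Compound 2

The source may report more compounds than this note shows. Statements on the series, on what has been measured and on what is new or still open speak of the compounds shown alone.

Compound 1 `Cc1ccc2cc(CN(Cc3ccc(C(C)C)cc3)Cc3ccccc3F)c(=O)[nH]c2c1`: > 33000 nM
Compound 2 `COCOc1ccc(CN(Cc2ccc(C(C)(C)C)cc2)Cc2cc3cc(C)ccc3[nH]c2=O)cc1`: 6400 nM
Compound 3 `CCc1ccc2[nH]c(=O)c(CN(Cc3ccc(OCOC)cc3)Cc3ccc(C(C)(C)C)cc3)cc2c1`: > 10000 nM

Within the data shown here, in a toxicity assay on MDCK cells (Canis lupus familiaris) for cytotoxicity, read by crystal violet staining, with a stated time of 48 h (on this read-out higher numbers stand for lower toxicity in this test and lower numbers for higher toxicity in this test), compound 2 gives the only number of the three, at 6400 nM. Compound 1 gives only a limit (the limit of > 33000 nM in this assay, at which 1 of the 3 values shown sits). Compound 3 likewise gives only a limit (the limit of > 10000 nM in this assay, at which 1 of the 3 values shown sits). Among the measured compounds shown here, the step of an at least 1.5-fold higher number from compound 2 to compound 3 (0.19 log units; that floor lies within the scatter) is the sole measured step, and it is within the scatter.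

Compound 4 `CCOc1ccc(CN(Cc2ccc(C(C)(C)C)cc2)Cc2cc3cc(C)ccc3[nH]c2=O)cc1` differs from compound 2 by methyl in place of methoxy on a saturated chain carbon bound to an oxygen on an aromatic ring. For the measured compounds named here, no measured step touches this position, and the one step known says nothing about it. Compound 4 is therefore expected to sit close to compound 2 in this assay, with a step of a 1.3-fold higher number from compound 2 to compound 4 (0.10 log units; within the scatter) that stays within the scatter. Compound 4 is estimated at 8000 nM, ranging from 3000 nM to 25000 nM.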

Compound 4, half-maximal cytotoxic concentration: > 10000 nM
Compound 4: no number, only a limit (the forecaster's own chance of this, stated with the estimate: 30%); at least 1.2-fold (0.09 log units) between middle value and limit.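

Among these compounds, replacing the 4-(methoxymethoxy)phenyl of compound 2 with the 4-ethoxyphenyl of compound 4 gives the first measured step at this position in this assay, an at least 1.5-fold higher number from compound 2 to compound 4 (0.19 log units; that floor lies within the scatter). Compound 4 gives only a limit, so this step is a floor and its true size cannot be read: the limit of > 10000 nM in this assay, at which 2 of the 4 values shown sit. The change therefore shows no step beyond the scatter, but it does not rule one out. As far as these compounds go, what compound 4 would give as an actual number stays open. So does how a longer chain such as propoxy, or an amine on the same chain, would read here.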